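Para Chloro Exchanged for Methyl: Cytotoxicity Outlook

The source may report more compounds than this note shows. Statements on the series, on what has been measured and on what is new or still open speak of the compounds shown alone.

Going by the values given here, compound 2 `Clc1ccc(OC(CCn2ccnc2)c2ccccc2)cc1` is one of only two compounds measured so far, and in a functional assay on U-937 cells (Homo sapiens) for cytotoxicity (on this read-out higher numbers stand for lower toxicity in this test and lower numbers for higher toxicity in this test), compound 2 gives 84900 nM. The other, compound 1 `Clc1ccc(OC(CCn2ccnc2)c2ccccc2)c(Cl)c1`, gives 56500 nM in this assay, a number within the scatter of that of compound 2. Among the compounds with values here, the single measured step between them, a 1.5-fold higher number from compound 1 to compound 2 (0.18 log units; within the scatter), exchanges a chloro for hydrogen on an aromatic carbon and stays within the scatter. Compound 3 `Cc1ccc(OC(CCn2ccnc2)c2ccccc2)cc1` differs from compound 2 by methyl in place of chloro on an aromatic carbon, so again one small group replaces another on the same aromatic carbon. Within the data shown here, only the step from compound 1 to compound 2 bears on this change, and it was small, so the expected movement in this assay is none beyond the scatter. The estimate for compound 3 in this assay is therefore 80000 nM, with a range from 35000 nM to 180000 nM. This corresponds to an expected step of a 1.1-fold lower number from compound 2 to compound 3 (0.03 log units; within the scatter).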

Compound 3, half-maximal cytotoxic concentration: 141000 nM
The estimate for compound 3 lay 1.8-fold (0.25 log units) below the measured number, within the range that was stated.
By their numbers in this assay, from the lowest: compounds 1, 2 and 3 (each within the scatter of the next, the first and the last beyond it).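

In this assay the exchange of chloro for methyl on an aromatic carbon para to a large group gives a 1.7-fold higher number from compound 2 to compound 3 (0.22 log units; within the scatter) and so stays within the scatter. The earlier step, a 1.5-fold higher number from compound 1 to compound 2 (0.18 log units; within the scatter), removed a second chloro and left this one in place, so the 4-chlorophenyl to 4-methylphenyl change is the first reading shown for this position itself. It shows that, among these two groups, replacing one heavy atom with another here brings no change beyond the scatter, and no measurement at hand offers a reason for this result.

The compounds shown leave open whether an amine, a carboxylic acid or a longer chain at this position would move the number in this assay beyond the scatter. They also leave open whether methyl in place of chloro behaves the same way with the second chloro of compound 1 present.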